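The source may hold more compounds than are shown below. What is called first, only, known or untested is meant among the compounds shown, and "the series" means these compounds.

Compound 1 `O=C1C(Nc2ccc(Br)cc2)=CC(=O)c2c1nc1n2[C@H]2OC[C@@H](O)[C@H]2OC1` and compound 2 `O=C1C=C(Nc2cccc(F)c2)C(=O)c2c1nc1n2[C@H]2OC[C@@H](O)[C@H]2OC1` share one core and differ only in the group carried on the amine nitrogen. In a functional assay on HeLa cells (Homo sapiens) for inhibition, read by sulforhodamine B assay (a lower number here means a stronger inhibitor, a higher number a weaker inhibitor), compound 1 gives 5220 nM, the lower of the two numbers recorded so far, and compound 2 gives 6440 nM; the gap between them lies within the scatter, so neither can be called the stronger inhibitor. Compound 3 `O=C1C(NC2CC2)=CC(=O)c2c1nc1n2[C@H]2OC[C@@H](O)[C@H]2OC1` has not yet been measured. It differs from compound 1 in one place: cyclopropyl in place of 4-bromophenyl on an amine nitrogen. Within the data shown here, no measured pair shows this exchange, so its effect can only be judged from the two measured compounds, both of which are weak. The expected change is a modest loss, a 1.5-fold higher number from compound 1 to compound 3 (0.19 log units; within the scatter), which may or may not exceed the scatter. In this assay compound 3 is therefore expected to give 8000 nM, with a range of 2500 nM to 25000 nM.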

Compound 3, half-maximal inhibitory concentration: > 16000 nM
Compound 3: a limit, no number (the forecaster's own chance of this, stated with the estimate: 15%); middle value at least 2.0-fold (0.30 log units) away from the limit.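

Among these compounds, compounds 1 and 2 gave no step at this position, so they could not show whether the group on the amine nitrogen matters in this assay. Exchanging 4-bromophenyl for cyclopropyl gives an at least 3.0-fold higher number from compound 1 to compound 3 (0.48 log units; beyond the scatter), which shows that this position does respond to the group it carries and that this small carbon ring does not hold the level of compound 1. Compound 3 stands at a limit and not a number, so the step has a floor but no measured size: the limit of > 16000 nM in this assay, at which 1 of the 3 values shown sits.

This single step cannot say whether the aromatic ring, the bromine or the size of the group accounts for the difference, and a plain phenyl, a benzyl group or a longer alkyl chain on the same nitrogen would help to separate these readings. As far as these compounds go, whether any group here would give a much lower number than compound 1 also stays open.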